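The compounds below may be only part of what the source reports. "The series", "measured", "known", "first", "only" and "open" are said of these compounds alone.

Series of aryl sulfonyl hydrazides. Compound 1 `Cc1cccc(NNS(=O)(=O)c2ccc(S(C)(=O)=O)cc2)c1` gives 43 nM in an assay for inhibition of Indoleamine 2,3-dioxygenase 1 (Homo sapiens), read by spectrophotometry, with stated times of 1 h and 4 h (on this read-out higher numbers stand for weaker inhibition and lower numbers for stronger inhibition), compound 2 `Cc1cccc(NNS(=O)(=O)c2ccc(C#N)cc2)c1` gives 59 nM, and compound 3 `CC(=O)Nc1ccc(S(=O)(=O)NNc2ccc(C)cc2)cc1` gives 51 nM; all three numbers lie within the scatter of one another, so compound 3 stands level with both neighbours. Going by the values given here, the only measured step, a 1.4-fold higher number from compound 1 to compound 2 (0.14 log units; within the scatter), altered the ring on the sulfonyl side. Compound 4 `CC(=O)Nc1ccc(S(=O)(=O)NNc2ccc(C#N)cc2)cc1` differs from compound 3 by cyano in place of methyl on an aromatic carbon, on the ring attached to the hydrazine nitrogen, so that step bears only loosely: it shows a cyano tolerated at one site, and says nothing direct about this one. Among the compounds with values here, with no closer precedent, the step expected in this assay is a 1.1-fold higher number from compound 3 to compound 4 (0.03 log units; within the scatter), not beyond the scatter. Compound 4 is therefore estimated at 55 nM, range 25 nM to 120 nM.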

Compound 4, half-maximal inhibitory concentration: 5670 nM
The estimate for compound 4 lay 100-fold (2.01 log units) below the measured number; measured number outside the range, above it.
By their numbers in this assay, from the lowest: compounds 1, 3 and 2 (each within the scatter of the next); then compound 4.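

In this assay, going by these compounds alone, cyano in place of methyl on an aromatic carbon para to a large group gives a 110-fold higher number from compound 3 to compound 4 (2.05 log units; beyond the scatter) and is the only step beyond the scatter. This site therefore does not share the tolerance for cyano seen on the sulfonyl side in a 1.4-fold higher number from compound 1 to compound 2 (0.14 log units; within the scatter) within the series. Nothing measured here accounts for the size of this step.

Only methyl and cyano are shown at this place, so it remains open whether cyano itself or the absence of methyl drives the step. A chlorine, a methoxy or an amine there would help separate the two readings.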